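Ethoxy Homologue of Compound 2: Expected Potency

The source may report more compounds than this note shows. Statements on the series, on what has been measured and on what is new or still open speak of the compounds shown alone.

In a functional assay on cells for positive allosteric modulation of G-protein coupled receptor 68 (Homo sapiens), read by a luciferase reporter and cAMP accumulation, with a stated time of 30 min, at pH 6.8 and pH 8.3, in the presence of a further agent that is not named here (on this read-out lower numbers stand for lower potency and higher numbers for higher potency (the scale is a negative logarithm)), compound 1 `Nc1nc(NCc2ccccc2)nc(-c2ccc(F)cc2CO)n1` gives 4.58. Going by the values given here, compound 2 `COc1ccc(-c2nc(N)nc(NCc3ccccc3)n2)c(CO)c1` gives 4.12 in this assay, the lowest of the two numbers so far; the single recorded step, a number 0.46 log units lower from compound 1 to compound 2 (beyond the scatter), separates it from compound 1. Compound 3 `CCOc1ccc(-c2nc(N)nc(NCc3ccccc3)n2)c(CO)c1` differs from compound 2 by methyl in place of hydrogen on a saturated chain carbon bound to an oxygen on an aromatic ring, so methoxy becomes ethoxy. Among the compounds with values here, no measured step touches this chain carbon: the recorded step concerns exchange of one ring substituent for another, not lengthening of the chain, and gives no direction. A change within the scatter is therefore expected, a number 0.02 log units lower from compound 2 to compound 3 (within the scatter). Compound 3 is expected to give 4.1, within 3.6 to 4.6.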

Compound 3, negative logarithm of the antagonist equilibrium constant: 4.37
Estimate against measurement, compound 3: 0.27 log units below; measured number inside the range.
By their numbers in this assay, from the lowest: compounds 2, 3 and 1 (each within the scatter of the next, the first and the last beyond it).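

In this assay, going by these compounds alone, methyl in place of hydrogen on this saturated chain carbon gives a number 0.25 log units higher from compound 2 to compound 3 (within the scatter) and is the first change to the chain seen. Ethoxy in place of fluoro gives a number 0.21 log units lower from compound 1 to compound 3 (within the scatter) while methoxy in place of fluoro stood beyond the scatter, so on this read-out ethoxy does not separate from fluoro as methoxy does. Nothing on hand accounts for these numbers.

From the compounds shown here alone, whether a longer chain such as propoxy, or an amine on this ring carbon, stays in this range remains open.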